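Methoxy in place of chloro: working notes on compound 3

This account rests on a few compounds, and the source may have more. Where it says the series, first, only, none or still open, it means among the compounds named here.

Measured values in a functional assay on HCT-116 cells (Homo sapiens) for cytotoxicity, read by MTT assay, with a stated time of 72 h (on this read-out lower numbers stand for stronger inhibition and higher numbers for weaker inhibition), are as follows
compound 1 `O=C(Nc1ccccc1)Nc1ccc(C(=O)NO)cc1` gives 14700 nM
compound 2 `O=C(Nc1ccc(Cl)cc1)Nc1ccc(C(=O)NO)cc1` gives the limit > 50000 nM

Compound 2 gives only a limit (> 50000 nM) and no number. Compound 3 `COc1ccc(NC(=O)Nc2ccc(C(=O)NO)cc2)cc1` has methoxy in place of chloro on an aromatic carbon, para to a large group (methoxy in place of chloro on an aromatic carbon). Going by the values given here, the only measured step bearing on this is an at least 3.4-fold higher number from compound 1 to compound 2 (0.53 log units; beyond the scatter) when chloro replaces hydrogen. Compound 3 is expected to lie nearer compound 1 (14700 nM), though methoxy itself remains unmeasured. A step to a lower number is expected (an at least 2.5-fold lower number from compound 2 to compound 3 (0.39 log units; beyond the scatter)). Compound 3 is estimated at 20000 nM (range 7000 nM to 50000 nM).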

Compound 3, half-maximal inhibitory concentration: 22300 nM
The estimate for compound 3 lay 1.1-fold (0.05 log units) below the measured number; the range from low to high includes it.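

In this assay, the change at this position, para to a large group, is not uniformly unfavourable: methoxy in place of chloro gives an at least 2.2-fold lower number from compound 2 to compound 3 (0.35 log units; beyond the scatter). Methoxy in place of hydrogen gives a 1.5-fold higher number from compound 1 to compound 3 (0.18 log units; within the scatter), so the rise seen with chloro does not carry over to methoxy. The size of the chloro-to-methoxy step stays open-ended, since compound 2 gives a limit and not a number: the limit of > 50000 nM in this assay, at which 1 of the 3 values shown sits.

As far as these compounds go, whether an amine or a longer alkoxy chain here would follow methoxy or chloro remains open. So does whether any group at this position can give a clearly lower number than hydrogen.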